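From Fluorine to Bromine on the Aryl Ring

This account rests on a few compounds, and the source may have more. Where it says the series, first, only, none or still open, it means among the compounds named here.

Three compounds share one core and differ only in the group on a saturated ring carbon. Compound 1 `CCCCCCCCCCCCCCCCCCNC(=O)[C@H]1CSC(C2CCCCC2)N1` bears a cyclohexyl there, compound 2 `CCCCCCCCCCCCCCCCCCNC(=O)[C@H]1CSC(c2cccc(O)c2)N1` a 3-hydroxyphenyl and compound 3 `CCCCCCCCCCCCCCCCCCNC(=O)[C@H]1CSC(c2ccc(F)cc2)N1` a 4-fluorophenyl. In a functional assay on LNCaP cells (Prostate gland, Homo sapiens) for antiproliferative activity, read by sulforhodamine B assay (on this read-out lower numbers stand for stronger inhibition and higher numbers for weaker inhibition), compound 1 gives 12800 nM, compound 2 gives 1700 nM and compound 3 gives 1900 nM. Compound 3 thus stands second highest of the three numbers: the step of a 6.7-fold lower number from compound 1 to compound 3 (0.83 log units; beyond the scatter) is clearly beyond the scatter, as is a 7.5-fold lower number from compound 1 to compound 2 (0.88 log units; beyond the scatter), while a 1.1-fold higher number from compound 2 to compound 3 (0.05 log units; within the scatter) lies within it, so compound 2 and compound 3 cannot be told apart.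

Compound 4 `CCCCCCCCCCCCCCCCCCNC(=O)[C@H]1CSC(c2ccc(Br)cc2)N1` is compound 3 with bromo in place of fluoro on an aromatic carbon. Within the data shown here, no measured step swaps one halogen for another, so this change has no direct precedent among the three. The closest guide is the exchange of one substituted phenyl for another, a 1.1-fold higher number from compound 2 to compound 3 (0.05 log units; within the scatter), which left the number essentially unchanged, and both aryl compounds stand far from compound 1. For compound 4 the expected step is a 1.3-fold lower number from compound 3 to compound 4 (0.10 log units; within the scatter), within the scatter. Compound 4 is expected to give about 1500 nM, in the range 600 nM to 4000 nM.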

Compound 4, half-maximal inhibitory concentration: 5100 nM
Estimate against measurement, compound 4: 3.4-fold (0.53 log units) below, and the stated range ends below it.
By their numbers in this assay, from the lowest: compounds 2 and 3 (each within the scatter of the next); then compound 4; then compound 1.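

Within this assay, the choice of halogen on this aromatic carbon, para to a large group, turns out to matter: the step with bromo in place of fluoro (a 2.7-fold higher number from compound 3 to compound 4 (0.43 log units; beyond the scatter)) is beyond the scatter, whereas the earlier exchange of one substituted phenyl for another showed no change that could be told from the scatter. Carrying a substituted phenyl therefore does not by itself settle the number, since compound 4 also separates from the other aryl compound (a 3.0-fold higher number from compound 2 to compound 4 (0.48 log units; beyond the scatter)), while keeping part of the advantage over the cyclohexyl compound (a 2.5-fold lower number from compound 1 to compound 4 (0.40 log units; beyond the scatter)). Nothing available here measures a property that could account for the difference between these two halogens.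

With only fluoro and bromo shown on this carbon, it remains open whether chloro would sit with compound 3 or with compound 4, and what an amine or a carboxylic acid in the same place would give. Going by these compounds, it is also open whether these steps would keep their size with a shorter chain in place of the long one shared by all four compounds.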